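Chain extension on two aryl ether cores

This account rests on a few compounds, and the source may have more. Where it says the series, first, only, none or still open, it means among the compounds named here.

Compound 1 `CCCCCCOc1cc(OC)c(Br)cc1C(C)=O` and compound 2 `CCCCCCCCOc1cc(OC)c(Br)cc1C(C)=O` share a core; compound 3 `CCCCCCCCCCCCOc1cc(OC)ccc1C(C)=O` and compound 4 `CCCCCCCCCCCCCCOc1cc(OC)ccc1C(C)=O` share another, and the difference between the two cores is not broken down here. In a functional assay, with a stated time of 10 min (on this read-out higher numbers stand for weaker inhibition and lower numbers for stronger inhibition), compound 1 gives 53100000 nM, compound 2 gives 38100000 nM and compound 3 gives 65600000 nM; all three values lie within the scatter of one another. The change ethyl in place of hydrogen on a saturated chain carbon, six bonds along the chain from an oxygen on an aromatic ring made the step of a 1.4-fold lower number from compound 1 to compound 2 (0.14 log units; within the scatter). The change ethyl in place of hydrogen on a saturated chain carbon, ten or more bonds along the chain from an oxygen on an aromatic ring is the same kind of change, differing only in where along the chain it sits. On this assay a step of about a 1.3-fold lower number from compound 3 to compound 4 (0.12 log units; within the scatter) is expected for compound 4, resting on the measured step of a 1.4-fold lower number from compound 1 to compound 2 (0.14 log units; within the scatter). Compound 4 is therefore estimated at 50000000 nM, between 25000000 nM and 100000000 nM.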

Compound 4, half-maximal inhibitory concentration: 57000000 nM
Compound 4: the middle estimate sits 1.1-fold (0.06 log units) below what was measured; the range from low to high includes it.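

In this assay, ethyl in place of hydrogen on the core of compound 3 gives a 1.2-fold lower number from compound 3 to compound 4 (0.06 log units; within the scatter), and this step agrees with the one on the core of compound 1: the same change on two cores in this assay, a 1.4-fold lower number (0.14 log units; within the scatter) from compound 1 to compound 2 and a 1.2-fold lower number (0.06 log units; within the scatter) from compound 3 to compound 4, 1.2-fold (0.08 log units) apart, within the scatter of two such steps. The change therefore reads the same on both cores, with no sign that the core alters its outcome. This does not show that the change affects inhibition, since each step lies within the scatter, and two pairs set no rule for other cores.

Going by these compounds, whether a longer chain than that of compound 4 would give a step beyond the scatter remains open. So does the outcome of an amine or a carboxylic acid at the chain end.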